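A few compounds are considered here, and "the series" means these few. Any claim that something is new, unique, unknown or untested is made for them only; others in the source may bear on it.

Compound 1 `CNc1nc(N)nc2c1ncn2/C=C1/CC1(CO)CO` reaches only the limit of an ADME assay on Akata cells (Homo sapiens) for cytotoxicity, with a stated time of 7 days; on this read-out higher numbers stand for lower toxicity in this test and lower numbers for higher toxicity in this test: compound 1 gives > 24000 nM, a limit and not a number.
Compound 2 `CCOc1nc(N)nc2c1ncn2/C=C1/CC1(CO)CO` likewise stops at a limit, > 20000 nM.
Compound 3 `CCCNc1nc(N)nc2c1ncn2/C=C1/CC1(CO)CO` again returns a limit, > 24000 nM.

Compound 1 therefore stands only at a limit in this assay, as do the two others. Compound 4 `Nc1nc(NC2CCCCC2)c2ncn(/C=C3/CC3(CO)CO)c2n1` carries the change (cyclohexyl in place of methyl on a nitrogen on an aromatic ring). The nearest measured step, a step that the two limits leave unreadable from compound 1 to compound 3, also enlarges the chain on the same nitrogen, yet its size is hidden by the limit of > 24000 nM in this assay, at which 2 of the 3 values shown sit. The steps a step that the two limits leave unreadable from compound 1 to compound 2 and a step that the two limits leave unreadable from compound 2 to compound 3 are equally unreadable, their ends sitting at the limit of > 20000 nM in this assay, at which 1 of the 3 values shown sits, and (the limit of > 24000 nM in this assay, at which 2 of the 3 values shown sit). No step beyond the scatter is expected for compound 4, a number no higher from compound 1 to compound 4 (the limit leaves the size open). Compound 4 is estimated at 24000 nM, between 10000 nM and 60000 nM.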

Compound 4, half-maximal cytotoxic concentration: > 24000 nM
Compound 4: only a limit was reported (the forecaster's own chance of this, stated with the estimate: 80%); the middle value sits exactly at the limit.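

For the compounds shown here, compound 4, like compound 1, compound 2 and compound 3, gives only a limit, so no step between compound 4 and any of them can be read. The compounds shown leave open what concentration would reach the half-maximal cytotoxic effect in this assay for any of these four compounds.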